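Amide substituent change on the shared lipopeptide core

The source may report more compounds than this note shows. Statements on the series, on what has been measured and on what is new or still open speak of the compounds shown alone.

Measured so far:
compound 1 `CCCCCCCCCCCC(=O)OC[C@H](CSC[C@@H](N)C(=O)NCCCC(C)(C)CO)OC(=O)CCCCCCCCCCC` gives 30700 nM
compound 2 `CCCCCCCCCCCC(=O)OC[C@H](CSC[C@@H](N)C(=O)NC(CC)COC)OC(=O)CCCCCCCCCCC` gives 71.8 nM

In an assay on HEK293 cells for agonist activity at Toll-like receptor 2 (Homo sapiens) (on this read-out lower numbers stand for an effect already at smaller amounts and higher numbers for an effect only at larger amounts of compound), compound 1 gives the highest of the two numbers; its nearest neighbour is compound 2, reached by a 430-fold lower number from compound 1 to compound 2 (2.63 log units; beyond the scatter), a step beyond the scatter. That step exchanges the 4-(hydroxymethyl)-4-methylpentyl group on the amide-type nitrogen for 1-(methoxymethyl)propyl.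

Compound 3 `CCCCCCCCCCCC(=O)OC[C@H](CSC[C@@H](N)C(=O)N[C@@H](CC)COCC(=O)O)OC(=O)CCCCCCCCCCC` is not yet measured. Against compound 1 the change is 1-((carboxymethoxy)methyl)propyl in place of 4-(hydroxymethyl)-4-methylpentyl on an amide-type nitrogen. The entering group shares the propyl branch and the ether linkage seen in compound 2, and extends it with a carboxymethyl.

Among the compounds with values here, the only measured step that bears on this change is the one from compound 1 to compound 2, and it was large. Within the data shown here, a step of similar direction is therefore expected for compound 3, though with less certainty about its size, since no measured step covers the carboxymethyl extension. Compound 3 is expected to show a 77-fold lower number from compound 1 to compound 3 (1.89 log units; beyond the scatter) in this assay. The estimated value for compound 3 is 400 nM, with a range from 50 nM to 4000 nM.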

Compound 3, half-maximal effective concentration: 6500 nM
Beside the measured number, compound 3's estimate is 16-fold (1.21 log units) below it; measured number above the stated range.
By their numbers in this assay, from the lowest: compound 2; then compound 3; then compound 1.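

In this assay, the low number reached with 1-(methoxymethyl)propyl on the amide-type nitrogen does not survive extension to 1-((carboxymethoxy)methyl)propyl, with a 91-fold higher number from compound 2 to compound 3 (1.96 log units; beyond the scatter). The propyl branch and ether linkage are present in both groups, so together they do not fix the read-out at this position; the end of the chain beyond the ether oxygen also matters. The extended group still keeps part of the difference from 4-(hydroxymethyl)-4-methylpentyl, with a 4.7-fold lower number from compound 1 to compound 3 (0.67 log units; beyond the scatter), although this step is far smaller than the one printed for the methoxy-ended group, and no measured evidence here accounts for the difference between the two groups.

The compounds shown do not separate the effect of the carboxylic acid from that of the longer chain; a methyl ester, a primary amide or a simple propoxy group in the same place would bear on that question. Also open, from the compounds shown here alone, is how the opposite configuration at the defined stereocentre of 1-((carboxymethoxy)methyl)propyl would read in this assay.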